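Trifluoromethyl to Methyl: One Change on Compound 2

A few compounds are considered here, and "the series" means these few. Any claim that something is new, unique, unknown or untested is made for them only; others in the source may bear on it.

Of the compounds shown here, two have so far been tested in a functional assay on the whole organism (strain Swiss) with Mus musculus as the target, in the maximal electroshock model, with a stated time of 0.25 h, at a dose of 300 mg/kg by the intraperitoneal route; a lower number here means a weaker effect, a higher number a stronger effect of the compound at the dose given. Compound 1, `CC(C(=O)N1CCN(c2ccccc2F)CC1)N1C(=O)CCC1=O`, gives 100% in that test. Compound 2, `CC(C(=O)N1CCN(c2cccc(C(F)(F)F)c2)CC1)N1C(=O)CCC1=O`, gives 75% in this assay. Among the compounds with values here, of these two numbers compound 2 stands lower, and its only neighbour, compound 1, lies higher by a margin beyond the usual scatter of the measurement. Compound 3, `Cc1cccc(N2CCN(C(=O)C(C)N3C(=O)CCC3=O)CC2)c1`, has not yet been measured. It differs from compound 2 in a single place: methyl in place of trifluoromethyl on an aromatic carbon. Within the data shown here, no pair of measured compounds isolates this change, so the expectation for compound 3 rests on where compound 2 stands and on the change itself. The step of a number 5 percentage points higher from compound 2 to compound 3 (within the scatter) is expected to be modest and, if anything, upward, rather than a clear move beyond the scatter. On that basis compound 3 is estimated to give 80% in this assay, with a likely range from 50% to 100%.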

Compound 3, a percentage reported as activity, at one dose (the size of the read-out at that dose, not a potency): 100%
For compound 3 the middle estimate is 20 percentage points below the measured one, and the stated range covers the measured number.
By their numbers in this assay, from the lowest: compound 2; then compounds 1 and 3 (each within the scatter of the next).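

In this assay, methyl in place of trifluoromethyl on an aromatic carbon is now isolated as a single change, and it brings a number 25 percentage points higher from compound 2 to compound 3 (beyond the scatter) at this place, meta to a large group. The earlier compounds shown here could not show this, since compound 1 and compound 2 differ in both the group and its place, so the group on this carbon is now seen to matter to the read-out at the dose given. The second comparison, 3-methylphenyl in place of 2-fluorophenyl on an amine nitrogen in a ring, gives no change at the digits printed from compound 1 to compound 3 (within the scatter) and so leaves these two aryl groups unseparated in this assay, while no information on any property of these groups bears on the result, and the step remains a description without an explanation.

What the compounds shown leave open is how this position would respond to a group other than methyl or trifluoromethyl, such as chlorine, a methoxy group or an amine. They also leave open whether the step from trifluoromethyl to methyl would hold at another dose or time.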